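The source may report more compounds than this note shows. Statements on the series, on what has been measured and on what is new or still open speak of the compounds shown alone.

In an assay on HEK-293T cells for inhibition of diacylglycerol lipase-alpha (Homo sapiens), read by colorimetric assay (on this read-out lower numbers stand for stronger inhibition and higher numbers for weaker inhibition), compound 1 `CC(=O)c1coc(C(=O)CCCCCCc2ccccc2)n1` gives 123 nM. Compound 2 `O=C(CCCCCCc1ccccc1)c1noc(-c2ccco2)n1` is a different case, since in this assay it reaches only a limit, > 10000 nM, and so stands at the limit of > 10000 nM in this assay, at which 1 of the 2 values shown sits. Compound 3 `O=C(CCCCCCc1ccccc1)c1noc(-c2ccccn2)n1` differs from compound 2 by a single change: pyridin-2-yl in place of furan-2-yl on an aromatic carbon. Going by the values given here, no measured pair shows what such a swap does here, so the expected step is none beyond the usual scatter, a number no higher from compound 2 to compound 3 (the limit leaves the size open). Compound 3 is therefore estimated at 10000 nM in this assay, with a range from 3000 nM to 30000 nM, and a limit rather than a number may again be all that is reported.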

Compound 3, half-maximal inhibitory concentration: > 10000 nM
Compound 3: only a limit was reported; the forecaster's own chance of this, stated with the estimate: 60%; the middle value sits exactly at the limit.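

No step can be read from compound 2 to compound 3, since each gives only a limit and not a number: the limit of > 10000 nM in this assay, at which 2 of the 3 values shown sit.

The compounds shown leave open whether pyridin-2-yl in place of furan-2-yl changes inhibition at all.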